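Swapping the Aryl Arm of a Bis-Benzylidene Cyclohexanone

The source may hold more compounds than are shown below. What is called first, only, known or untested is meant among the compounds shown, and "the series" means these compounds.

Measured compounds:
compound 1 `COc1cccc(/C=C2\CCC/C(=C\c3cccc(Br)c3)C2=O)c1OC` — 12200 nM
compound 2 `COc1cccc(/C=C2\CCC/C(=C\c3ccc(Cl)cc3Cl)C2=O)c1OC` — > 20000 nM
compound 3 `COc1ccc(/C=C2\CCC/C(=C\c3ccc(Cl)cc3)C2=O)cc1OC` — 4800 nM

In a functional assay on HT-1080 cells (Homo sapiens) for cytotoxicity, read by MTT assay, with a stated time of 72 h (on this read-out lower numbers stand for stronger inhibition and higher numbers for weaker inhibition), compound 3 stands lowest of the two numbers, with compound 1 nearest at a gap beyond the scatter. Compound 2 gives only a limit in this assay, (the limit of > 20000 nM in this assay, at which 1 of the 3 values shown sits), not a number. Compound 4 `COc1cc(/C=C2\CCC/C(=C\c3ccc(OC)c(OC)c3)C2=O)ccc1O` differs from compound 3 in one place: 4-hydroxy-3-methoxyphenyl in place of 4-chlorophenyl on a double-bonded chain carbon bound to a double-bonded ring carbon. For the measured compounds named here, the one measured step, an at least 1.6-fold higher number from compound 1 to compound 2 (0.21 log units; that floor lies within the scatter), also swaps the aryl on that same chain carbon and stays within the scatter, so no step beyond the scatter is expected here, as a 1.0-fold higher number from compound 3 to compound 4 (0.02 log units; within the scatter). Compound 4 is therefore estimated at 5000 nM, expected between 2000 nM and 15000 nM.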

Compound 4, half-maximal inhibitory concentration: 4600 nM
Beside the measured number, compound 4's estimate is 1.1-fold (0.04 log units) above it; the range from low to high includes it.
By their numbers in this assay, from the lowest: compounds 4 and 3 (each within the scatter of the next); then compound 1. At a limit, above all of these: compound 2.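

In this assay, for the compounds shown here, the step at this chain carbon, a 1.0-fold lower number from compound 3 to compound 4 (0.02 log units; within the scatter), joins two true numbers, which the one earlier step did not. It shows that 4-hydroxy-3-methoxyphenyl can take the place of 4-chlorophenyl without a readable shift, even though the entering arm carries a hydrogen-bond donor and acceptors that the leaving arm lacks. Nothing given here speaks to why these two arms read alike. Still open, from the compounds shown here alone, is whether an amine or a carboxylic acid on this arm, or a longer chain there, would hold the number as well.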